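Two pyrimidinone pairs and a methylsulfanyl-for-aminoamino swap

The source may hold more compounds than are shown below. What is called first, only, known or untested is meant among the compounds shown, and "the series" means these compounds.

Of the compounds shown here, three have been measured in a functional assay on microsomes for inhibition, with a stated time of 1 h; a lower number here means a stronger inhibitor, a higher number a weaker inhibitor. Compound 1 `CN(C)c1ccc(-c2nc(NN)n(C)c(=O)c2C#N)cc1` gives 63 ug/mL. Compound 2 `CSc1nc(-c2ccccc2O)c(C#N)c(=O)n1C` gives 44 ug/mL, and compound 3 `Cn1c(NN)nc(-c2ccccc2O)c(C#N)c1=O` gives 34 ug/mL. Compound 3 and compound 2 differ in one place, (methylsulfanyl in place of aminoamino on an aromatic carbon), and the step of a 1.3-fold higher number from compound 3 to compound 2 (0.11 log units; within the scatter) lies within the scatter. The difference between the core of compound 1 and the core of compound 3 is not broken down here.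

Compound 4 `CSc1nc(-c2ccc(N(C)C)cc2)c(C#N)c(=O)n1C` has not been measured. It differs from compound 1 by methylsulfanyl in place of aminoamino on an aromatic carbon. This is the same kind of change as that from compound 3 to compound 2, but the surroundings differ: in compound 1 the place is meta to a group of 9 heavy atoms, whereas in compound 3 it is meta to a group of 7 heavy atoms. Since the earlier swap gave a step within the scatter, the step of a 1.2-fold higher number from compound 1 to compound 4 (0.08 log units; within the scatter) is expected to be of about the same size, because compound 1 stands at 63 ug/mL. Compound 4 is therefore estimated at 75 ug/mL, between 35 ug/mL and 160 ug/mL.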

Compound 4, half-maximal inhibitory concentration: 98 ug/mL
Beside the measured number, compound 4's estimate is 1.3-fold (0.12 log units) below it; low and high end bracket the measured number.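

In this assay, putting methylsulfanyl in place of aminoamino on the core of compound 1 gives a 1.6-fold higher number from compound 1 to compound 4 (0.19 log units; within the scatter). Set beside the same swap on the core of compound 3, the new step shows no sign that the core alters the outcome: the same change on two cores in this assay, a 1.3-fold higher number (0.11 log units; within the scatter) from compound 3 to compound 2 and a 1.6-fold higher number (0.19 log units; within the scatter) from compound 1 to compound 4, 1.2-fold (0.08 log units) apart, within the scatter of two such steps On these two cores, then, the change carries over as a step too small to read, but this does not show that methylsulfanyl and aminoamino are interchangeable in general, and two pairs cannot show that the step would stay this small on any further core.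

The compounds shown leave open whether any other group on that aromatic carbon would move the number beyond the scatter, such as a simple amine, a methoxy group or a longer chain like butylsulfanyl. They also leave open what a carboxylic acid in place of the cyano group would do on either core.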